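Ring-nitrogen substituent series: working notes toward compound 4

The compounds below may be only part of what the source reports. "The series", "measured", "known", "first", "only" and "open" are said of these compounds alone.

Measured so far:
compound 1 `COc1ccc(-c2cnc3nc(N)nc(N4CCN(C(=O)c5ccccc5)CC4)c3n2)cc1OC` — 400 nM
compound 2 `COc1ccc(-c2cnc3nc(N)nc(N4CCN(Cc5ccccc5F)CC4)c3n2)cc1OC` — 700 nM
compound 3 `COc1ccc(-c2cnc3nc(N)nc(N4CCN(Cc5c(Cl)cccc5Cl)CC4)c3n2)cc1OC` — 7600 nM

All three share one core and differ only in the group on an amine nitrogen in a ring. In a functional assay on cells (T-cell, Homo sapiens) for inhibition (on this read-out higher numbers stand for weaker inhibition and lower numbers for stronger inhibition), compound 3 gives the highest number of the three: the step of a 19-fold higher number from compound 1 to compound 3 (1.28 log units; beyond the scatter) and the step of an 11-fold higher number from compound 2 to compound 3 (1.04 log units; beyond the scatter) are both beyond the scatter, whereas a 1.8-fold higher number from compound 1 to compound 2 (0.24 log units; within the scatter) is within it.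

Compound 4 `COc1ccc(-c2cnc3nc(N)nc(N4CCN(C(=O)Nc5ccc(C#N)cc5)CC4)c3n2)cc1OC` is not yet measured. Its change from compound 3: (4-cyanophenyl)carbamoyl in place of 2,6-dichlorobenzyl on an amine nitrogen in a ring

Among the measured compounds shown here, two measured steps bear on this change, both ending at compound 3: a 19-fold higher number from compound 1 to compound 3 (1.28 log units; beyond the scatter) and an 11-fold higher number from compound 2 to compound 3 (1.04 log units; beyond the scatter). Of these, the step from compound 1 is the closer guide, since the entering (4-cyanophenyl)carbamoyl, like the benzoyl of compound 1, places a carbonyl on the amine nitrogen in a ring, while the leaving 2,6-dichlorobenzyl does not. The return of a carbonyl-bearing group is therefore expected to undo most of that large step: the expected step is a 13-fold lower number from compound 3 to compound 4 (1.10 log units; beyond the scatter), a lower number in this assay. For the measured compounds named here, for compound 4 the estimate in this assay is 600 nM, with a range of 150 nM to 2500 nM; no measured compound carries a carbamoyl or a nitrile, so the range is kept wide.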

Compound 4, half-maximal inhibitory concentration: 74 nM
Compound 4: middle estimate off by 8.1-fold (0.91 log units), on the high side; measured number below the stated range.
By their numbers in this assay, from the lowest: compound 4; then compounds 1 and 2 (each within the scatter of the next); then compound 3.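

In this assay, among the compounds shown here, (4-cyanophenyl)carbamoyl is the first group on this amine nitrogen in a ring to give a number beyond the scatter below all the others, with a 100-fold lower number from compound 3 to compound 4 (2.01 log units; beyond the scatter) and a 9.5-fold lower number from compound 2 to compound 4 (0.98 log units; beyond the scatter) as well as a 5.4-fold lower number from compound 1 to compound 4 (0.73 log units; beyond the scatter) in this series. The last step is the closest comparison, since both groups place a carbonyl on that nitrogen, and it shows that the number still moves with what is attached to the carbonyl carbon, here (4-cyanophenyl)amino in place of phenyl. No measurement shown gives a reason for these steps.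

On these data alone, the amide hydrogen and the nitrile enter together, so their separate shares in the step from compound 1 remain open. A plain phenylcarbamoyl and a 4-cyanobenzoyl would separate the two, and a methoxy or carboxylic acid in place of the nitrile would test how much that end of the group matters.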